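The compounds below may be only part of what the source reports. "The series", "measured", "known", "first", "only" and "open" are said of these compounds alone.

Compound 1 `C[C@H](CN1CCCC(C)(C)C1)NC(=O)c1ccc(-c2noc(C(F)(F)F)n2)cc1`: in an assay on isolated protein for inhibition of histone deacetylase 4 (Homo sapiens), read by fluorescence (on this read-out lower numbers stand for stronger inhibition and higher numbers for weaker inhibition), compound 1 gives 2 nM.
Compound 2 `C[C@H](CN1CCC(F)CC1)NC(=O)c1ccc(-c2noc(C(F)(F)F)n2)cc1`: in this assay compound 2 gives 30 nM.

Within the data shown here, compound 2 stands highest of the two numbers, and the single step recorded, a 15-fold higher number from compound 1 to compound 2 (1.18 log units; beyond the scatter), is the only comparison available. Compound 3 `C[C@H](CN1CCC(F)(F)CC1)NC(=O)c1ccc(-c2noc(C(F)(F)F)n2)cc1` differs from compound 2 by fluoro in place of hydrogen on a saturated ring carbon. Among the measured compounds shown here, no measured step bears directly on this change: the one step known exchanges the whole ring substituent rather than adding a second fluoro, so it offers no guide. The expectation for this assay is therefore no step beyond the scatter, no change at the digits printed from compound 2 to compound 3 (within the scatter). Compound 3 is estimated at 30 nM, within 12 nM to 80 nM.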

Compound 3, half-maximal inhibitory concentration: 130 nM
Compound 3: the middle estimate sits 4.3-fold (0.64 log units) below what was measured; the measured number lies above the stated range.
By their numbers in this assay, from the lowest: compound 1; then compound 2; then compound 3.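

In this assay, adding a second fluoro to the same saturated ring carbon is not neutral: it weakens inhibition (a 4.3-fold higher number from compound 2 to compound 3 (0.64 log units; beyond the scatter)). Among these compounds, measured against 3,3-dimethylpiperidin-1-yl, the 4,4-difluoropiperidin-1-yl group gives a larger loss than the single step from the monofluoro compound (a 65-fold higher number from compound 1 to compound 3 (1.81 log units; beyond the scatter)), and the three ring substituents now fall in a clear order of numbers. Nothing measured here accounts for this change. The compounds shown leave open how a hydroxyl or a methyl group in place of the fluoro would read at this ring carbon. They also leave open whether the order of these three substituents would hold with a different group on the shared core.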